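Ethyl on the ring amine of compound 3

The source may hold more compounds than are shown below. What is called first, only, known or untested is meant among the compounds shown, and "the series" means these compounds.

Working notes on a small set measured in an assay on membranes from brain for displacement of a labelled ligand from Neuronal acetylcholine receptor; alpha4/beta2 (Rattus norvegicus); a lower number here means a stronger inhibitor, a higher number a weaker inhibitor. Compound 1 `Brc1ccc(N2C[C@H]3CNC[C@H]3C2)cn1` gives 0.28 nM in this assay. Compound 2 `c1ccc(-c2ccc(N3C[C@H]4CNC[C@H]4C3)cc2)cc1` gives only a limit of the assay, > 10000 nM, and no number. Among the compounds with values here, compound 3 `c1ccc(-c2ccc(N3C[C@H]4CNC[C@H]4C3)nn2)cc1` gives 5320 nM in this assay; among the two numbers in hand this stands highest, and the one neighbour with a number, compound 1, sits far below it, beyond the scatter. The remaining entry is a limit (the limit of > 10000 nM in this assay, at which 1 of the 3 values shown sits).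

Compound 4 `CCN1C[C@@H]2CN(c3ccc(-c4ccccc4)nn3)C[C@@H]2C1` differs from compound 3 in one place: ethyl in place of hydrogen on an amine nitrogen in a ring. Within the data shown here, no measured pair covers this change, so the expectation rests on compound 3 alone. The step from compound 3 to compound 4 is expected to be modest and towards a higher number, a 1.7-fold higher number from compound 3 to compound 4 (0.23 log units; within the scatter). Compound 4 is therefore estimated at 9000 nM in this assay, with a likely range from 2500 nM to 30000 nM; a report of only a limit is a real possibility.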

Compound 4, inhibition constant: > 100000 nM
Compound 4: no number, only a limit; the forecaster's own chance of this, stated with the estimate: 35%; middle value at least 11-fold (1.04 log units) from the limit.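

Compound 4 gives only a limit of the assay and no number: the limit of > 100000 nM in this assay, at which 1 of the 4 values shown sits. Even so, the step can be read as a minimum: ethyl in place of hydrogen on an amine nitrogen in a ring gives an at least 18-fold higher number from compound 3 to compound 4 (1.27 log units; beyond the scatter) in this assay. Within the data shown here, this is the first measured change on this nitrogen, and it shows that the number can still rise sharply from a compound that already stands as high as compound 3, so this position does not accept ethyl without loss.

From the compounds shown here alone, the full size of the step stays open, and so does whether ethyl has a similar effect on the stronger compound 1. Also open, going by these compounds, is how a methyl, a longer chain such as propyl, or an acetyl group on this nitrogen would read, and whether any effect scales with the size of the group.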